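This account rests on a few compounds, and the source may have more. Where it says the series, first, only, none or still open, it means among the compounds named here.

Measured so far in a functional assay on HCT-15 cells (Homo sapiens) for inhibition, read by sulforhodamine B assay, with a stated time of 48 h, tested at 10 uM; on this read-out higher numbers stand for more inhibition at the one concentration tested (going by the name of the read-out) and lower numbers for less inhibition:
compound 1 `Brc1cn2ccnc2c(-c2ccc3ncn(C4CCCCC4)c3c2)n1` gives 13.1%;
compound 2 `O=Cc1ccc(-c2cn3ccnc3c(-c3ccc4ncn(C5CCCCC5)c4c3)n2)cc1` gives 49.1%;
compound 3 `Fc1ccc(-c2cn3ccnc3c(-c3ccc4ncn(C5CCCCC5)c4c3)n2)cc1` gives 7.59%.

Compound 3 stands lowest of the three numbers, although its gap to compound 1 lies within the scatter; only compound 2 is clearly apart, as a number 41.5 percentage points lower from compound 2 to compound 3 (beyond the scatter) shows. Compound 4 `c1cn2cc(-c3ccsc3)nc(-c3ccc4ncn(C5CCCCC5)c4c3)c2n1` differs from compound 3 in one place: thiophen-3-yl in place of 4-fluorophenyl on an aromatic carbon. Within the data shown here, no measured step swaps exactly these two groups. Among the measured compounds shown here, the steps that bear on it change the same position: a number 36 percentage points higher from compound 1 to compound 2 (beyond the scatter) and a number 5.5 percentage points lower from compound 1 to compound 3 (within the scatter). Only the formyl-bearing ring raised inhibition; compound 4, like compound 3, carries no formyl group. Because a number 5.5 percentage points lower from compound 1 to compound 3 (within the scatter) was within the scatter, a step within the scatter is expected for a number 4.4 percentage points higher from compound 3 to compound 4 (within the scatter). Compound 4 is estimated at 12%, ranging from 0% to 35%.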

Compound 4, a percentage reported as inhibition, at one concentration (the size of the read-out at that concentration, not a potency): 1.37%
Estimate against measurement, compound 4: 10.6 percentage points above; low and high end bracket the measured number.
By their numbers in this assay, from the lowest: compounds 4, 3 and 1 (each within the scatter of the next, the first and the last beyond it); then compound 2.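

In this assay, thiophen-3-yl in place of 4-fluorophenyl gives a number 6.2 percentage points lower from compound 3 to compound 4 (within the scatter), so this change of ring at this position makes no readable difference. Against the formyl-bearing ring the same group gives a number 47.7 percentage points lower from compound 2 to compound 4 (beyond the scatter), which leaves compound 2 alone in showing a clear gain from a ring here. Against bromo it gives a number 11.7 percentage points lower from compound 1 to compound 4 (beyond the scatter), the first step beyond the scatter that goes downward from compound 1. On these data alone, whether a phenyl ring carrying a carboxylic acid or an amine in place of formyl would match compound 2 remains open. Nothing given here explains these steps.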